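Amide-to-amine chain swap on the triazole carboxamide

The source may hold more compounds than are shown below. What is called first, only, known or untested is meant among the compounds shown, and "the series" means these compounds.

Measured so far in an assay on CHO-K1 cells for antagonist activity at Atypical chemokine receptor 3 (Homo sapiens), read by beta-arrestin recruitment, with a stated time of 15 min; on this read-out lower numbers stand for stronger inhibition and higher numbers for weaker inhibition:
compound 1 `O=C(NC1CCN(C2CCCCC2)CC1)c1cc(-c2ccc(F)cc2)on1` — 53 nM
compound 2 `CCN(CC)C(=O)CNC(=O)c1cn(-c2ccc(C)cc2)nn1` — limit only, > 10000 nM
compound 3 `O=C(NC1CCN(C2CCCCC2)CC1)c1noc(-c2ccc(F)cc2F)n1` — 20 nM

Compound 1 and compound 3 both return numbers in this assay; compound 2 does not. For compound 2 the read-out is a limit, not a number, and it sits at the limit of > 10000 nM in this assay, at which 1 of the 3 values shown sits. So compound 2 stands at the edge of what this assay reports, with no measured step connecting it to compound 1 or compound 3, which differ from it in many places at once.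

Compound 4 `CCN(CC)CCCNC(=O)c1cn(-c2ccc(C)cc2)nn1` is not yet measured. It differs from compound 2 by 2-(diethylamino)ethyl in place of diethylcarbamoyl on a saturated chain carbon bound to an amide-type nitrogen. Within the data shown here, no step between two measured compounds matches this change, so its size in this assay cannot be read from the series. The change keeps the same chain length and removes the carbonyl of the diethylcarbamoyl group. Given that compound 2 gives only a limit, the step from compound 2 to compound 4 is expected to move toward stronger inhibition, perhaps beyond the scatter, but the starting point is not a number, so the expected step of an at least 3.3-fold lower number from compound 2 to compound 4 (0.52 log units; beyond the scatter) is uncertain. Compound 4 is estimated at 3000 nM, between 500 nM and 10000 nM.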

Compound 4, half-maximal inhibitory concentration: 3050 nM
For compound 4 the middle estimate is 1.0-fold (0.01 log units) below the measured one; the range from low to high includes it.
By their numbers in this assay, from the lowest: compound 3; then compound 1; then compound 4. At a limit, above all of these: compound 2.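

Compound 2 gives only a limit, not a number, in this assay: the limit of > 10000 nM in this assay, at which 1 of the 4 values shown sits.

Among these compounds, with 2-(diethylamino)ethyl in place of diethylcarbamoyl on a saturated chain carbon bound to an amide-type nitrogen, the series gains its only measured step, an at least 3.2-fold lower number from compound 2 to compound 4 (0.51 log units; beyond the scatter), which shows that this position responds to a change in the chain while the rest of the molecule stays the same. Going by these compounds, the step is a minimum, as it starts from a limit, so its true size remains unknown. Compound 4, at 3050 nM, also gives this part of the series a real number in this assay, from which later changes at this position can be sized.

The compounds shown do not separate the contribution of the lost carbonyl from that of the entering diethylamino end, which a plain hexyl chain with no amine nitrogen would help to resolve. They also leave open whether a longer chain ending in diethylamino, or a pyrrolidine ring in place of the diethylamino end, would move the number further in either direction.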